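The source may report more compounds than this note shows. Statements on the series, on what has been measured and on what is new or still open speak of the compounds shown alone.

Measured in a functional assay on HepG2 cells (Homo sapiens) for antiproliferative activity, read by MTT assay, with a stated time of 72 h (a higher number here means a weaker inhibitor, a lower number a stronger inhibitor), so far:
Compound 1 `COc1ncc(-c2ccc3c(c2)N(C2CCCCC2)C(=O)CO3)cc1NS(=O)(=O)c1ccc(F)cc1`: > 40000 nM (a limit of the assay)
Compound 2 `CC(C)N1C(=O)COc2ccc(-c3cccc(NS(=O)(=O)c4ccc(F)cc4)c3)cc21`: > 40000 nM (a limit of the assay)

Compound 2 has no number, only a limit of the assay. Among the measured compounds shown here, the series so far stands at the limit of > 40000 nM in this assay, at which 2 of the 2 values shown sit, and offers no measured step.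

Compound 3 `O=C1COc2ccc(-c3cccc(NS(=O)(=O)c4ccc(F)cc4)c3)cc2N1c1ccc(F)cc1` carries 4-fluorophenyl in place of isopropyl on an amide-type nitrogen in a ring in the core it shares with compound 2. For the measured compounds named here, with no measured step to size this change in this assay the expectation is little or no gain, and any shift should be toward stronger inhibition. The expected move an at least 1.3-fold lower number from compound 2 to compound 3 (0.12 log units; that floor lies within the scatter) is therefore small. For compound 3 the estimated value is 30000 nM with an expected range of 10000 nM to 60000 nM and a reading at the limit again is the likelier outcome.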

Compound 3, half-maximal inhibitory concentration: > 40000 nM
Compound 3: only a limit was reported; the forecaster's own chance of this, stated with the estimate: 65%; at least 1.3-fold (0.12 log units) between middle value and limit.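

No step can be read between compound 2 and compound 3, as both give only a limit of the assay in this assay, not a number: the limit of > 40000 nM in this assay, at which 3 of the 3 values shown sit.

The compounds shown leave open whether any group on the amide-type nitrogen in a ring gives a measurable value in this assay.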